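Working notes on compound 3, expected from compounds 1 and 2

A few compounds are considered here, and "the series" means these few. Any claim that something is new, unique, unknown or untested is made for them only; others in the source may bear on it.

Measured so far:
compound 1, `Cc1ccccc1Oc1cccc(COc2ccccc2CCC(=O)OCCCOP(=O)(O)OC[C@H](N)C(=O)O)c1`: 20.3%
compound 2, `CCc1ccc(Oc2cccc(COc3ccccc3CCC(=O)OCCCOP(=O)(O)OC[C@H](N)C(=O)O)c2)cc1`: 19.3%

In an assay on cells for agonist activity at probable G-protein coupled receptor 34 (Mus musculus), with a stated time of 1 h (a lower number here means a smaller maximal response, a higher number a larger maximal response), compound 1 gives 20.3%, the highest of the two numbers, with compound 2 as its nearest neighbour; the step of a number 1 percentage points lower from compound 1 to compound 2 (within the scatter) is within the scatter, so neither compound can be ranked above the other.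

Compound 3, `CC(C)(C)c1ccc(Oc2cccc(COc3ccccc3CCC(=O)OCCCOP(=O)(O)OC[C@H](N)C(=O)O)c2)cc1`, is the unmeasured member. It differs from compound 1 by 4-(tert-butyl)phenyl in place of 2-methylphenyl on an oxygen on an aromatic ring. Going by the values given here, the only measured step that bears on this change is the one from compound 1 to compound 2, a change at the same place and of the same kind, from 2-methylphenyl to 4-ethylphenyl; it amounted to a number 1 percentage points lower from compound 1 to compound 2 (within the scatter), which is within the scatter. The shared core and the ester-linked chain are unchanged in compound 3.

With a single relevant step that stayed within the scatter, no step beyond the scatter is expected in this assay; the expected change is a number 0.3 percentage points lower from compound 1 to compound 3 (within the scatter). The estimate for compound 3 is therefore 20%, with a range from 10% to 30%.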

Compound 3, largest response reached (Emax), in percent of the reference or control that the assay uses: 16.9%
Compound 3: middle estimate off by 3.1 percentage points, on the high side, and the stated range covers the measured number.
By their numbers in this assay, from the lowest: compounds 3, 2 and 1 (each within the scatter of the next).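

In this assay, 4-(tert-butyl)phenyl in place of 2-methylphenyl on an oxygen on an aromatic ring gives a number 3.4 percentage points lower from compound 1 to compound 3 (within the scatter), while tert-butyl in place of ethyl on an aromatic carbon gives a number 2.4 percentage points lower from compound 2 to compound 3 (within the scatter). The earlier pair covered only the exchange of 2-methylphenyl for 4-ethylphenyl, whereas these steps extend the comparison to a group of 10 heavy atoms in place of one of 7 and show that this position accepts 4-(tert-butyl)phenyl with no step beyond the scatter, so compound 1, compound 2 and compound 3 cannot be ranked on this read-out. No information at hand accounts for this result.

Whether an amine or a carboxylic acid on this aromatic ring would give a step beyond the scatter remains open, since every group shown at this place is an alkyl-substituted phenyl. The compounds shown also differ only at this one place, which leaves open how the response would follow a longer chain in place of the ester-linked chain.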